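The source may hold more compounds than are shown below. What is called first, only, known or untested is meant among the compounds shown, and "the series" means these compounds.

Measured compounds in an assay on HEK293 cells for displacement of a labelled ligand from growth hormone secretagogue receptor type 1 (Homo sapiens), with a stated time of 60 min; on this read-out lower numbers stand for stronger inhibition and higher numbers for weaker inhibition:

- compound 1 `Cc1ncccc1-c1nc2cn(-c3cccc(OC(C)C)c3)nc2c(=O)n1C[C@H]1CCCN(C[C@H]2CCCO2)C1` gives 11 nM
- compound 2 `COc1cccc(-n2cc3nc(-c4cccnc4C)n(C[C@H]4CCCN(CC5CCC5)C4)c(=O)c3n2)c1` gives 1.6 nM
- compound 3 `COc1cccc(-n2cc3nc(-c4cccnc4C)n(C[C@H]4CCCN(CC5CCOC5)C4)c(=O)c3n2)c1` gives 60 nM

Compound 3 stands highest of the three numbers in this assay. Compound 1 is nearest, with a lower number beyond the scatter, and compound 2 is furthest, with a lower number still. Among the compounds with values here, compound 1 also differs from compounds 2 and 3 in more than one place, so no single step is drawn between it and compound 3.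

Compound 4 `COc1cccc(-n2cc3nc(-c4cccnc4C)n(C[C@H]4CCCN(Cc5cnco5)C4)c(=O)c3n2)c1` differs from compound 3 by 1,3-oxazol-5-yl in place of oxolan-3-yl on a saturated chain carbon bound to an amine nitrogen in a ring. Within the data shown here, the one measured step at the same place is a 38-fold higher number from compound 2 to compound 3 (1.57 log units; beyond the scatter). Among the measured compounds shown here, that step exchanged one saturated carbocycle for a saturated ring with one oxygen; the present change exchanges that saturated ring for an aromatic one with two hetero atoms, and no measured pair covers such a change. The earlier step shows that this position is sensitive and that a large shift in either direction is possible, but it does not fix a direction here. The expectation is therefore a step of uncertain sign, most likely modest, with a wide range.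

Compound 4 is expected to give about 40 nM in this assay, between 10 nM and 160 nM. This estimate corresponds to a step of a 1.5-fold lower number from compound 3 to compound 4 (0.18 log units; within the scatter).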

Compound 4, half-maximal inhibitory concentration: 120 nM
Beside the measured number, compound 4's estimate is 3.0-fold (0.48 log units) below it, within the range that was stated.
By their numbers in this assay, from the lowest: compound 2; then compound 1; then compounds 3 and 4 (each within the scatter of the next).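

In this assay the saturated oxolan-3-yl and the aromatic 1,3-oxazol-5-yl are not separated on this saturated chain carbon bound to an amine nitrogen in a ring: a 2.0-fold higher number from compound 3 to compound 4 (0.30 log units; within the scatter) lies within the scatter, although the ring changes from non-aromatic to aromatic and gains a hetero atom. Cyclobutyl now stands apart from two different hetero rings rather than one, with a 75-fold higher number from compound 2 to compound 4 (1.88 log units; beyond the scatter) as a large step in the same direction as a 38-fold higher number from compound 2 to compound 3 (1.57 log units; beyond the scatter) in this assay and the sensitivity of this position no longer resting on a single pair. Nothing available here explains the large steps or the lack of separation of the two hetero rings.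

The compounds shown leave open whether a hetero atom in the ring goes with the higher numbers or whether cyclobutyl is a special case, a question that a phenyl or a cyclopentyl group on the same carbon would address. They also leave open whether the large steps persist with a longer chain leading from the amine nitrogen to the ring.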